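Replacing the primary amide of compound 1 with an acyl oxadiazole

This account rests on a few compounds, and the source may have more. Where it says the series, first, only, none or still open, it means among the compounds named here.

Compound 1 `CCN1CCc2c(sc(NC(=O)Nc3ccc(Cl)cc3)c2C(N)=O)C1` is the point of departure. In a functional assay (strain AB) with Danio rerio as the target, read by microscopy, with a stated time of 1 h (on this read-out higher numbers stand for an effect only at larger amounts of compound and lower numbers for an effect already at smaller amounts), compound 1 gives 3120 nM; of the two plain numbers shown it is the higher one. Compound 2 `NC(=O)c1c(NC(=O)Nc2ccc(Cl)cc2)sc2c1CCN(CCCNC(=O)CCc1cccnc1)C2` carries a longer chain on the ring nitrogen, and in this assay compound 2 gives 470 nM, which is a 6.6-fold lower number from compound 1 to compound 2 (0.82 log units; beyond the scatter). Compound 3 `CC(C)(C)OC(=O)N1CCc2c(sc(NC(=O)Nc3ccc(Cl)cc3)c2C(N)=O)C1` reaches only a limit of this assay, > 25000 nM, so its change is an at least 8.0-fold higher number from compound 1 to compound 3 (0.90 log units; beyond the scatter). That limit is described as the limit of > 25000 nM in this assay, at which 1 of the 3 values shown sits.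

Compound 4 `CCN1CCc2c(sc(NC(=O)Nc3ccc(Cl)cc3)c2C(=O)c2nc(C)no2)C1` differs from compound 1 in another place: 3-methyl-1,2,4-oxadiazol-5-yl in place of amino on a carbonyl carbon. Neither measured step touches this carbonyl; both concern the ring nitrogen, and the first shows that a change there can be helpful while the second shows it can be harmful. For the amide itself the set holds no evidence, and the group that leaves carries the only hydrogen-bond donor counted there. The expectation is therefore a cautious one: compound 4 is estimated to give a somewhat higher number, a step of a 2.6-fold higher number from compound 1 to compound 4 (0.41 log units; beyond the scatter), with a best estimate of 8000 nM and a range from 2000 nM to 25000 nM.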

Compound 4, half-maximal effective concentration: > 25000 nM
Compound 4 was reported as a limit; the forecaster's own chance of this, stated with the estimate: 25%; at least 3.1-fold (0.49 log units) between middle value and limit.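

Going by these compounds alone, until now the only steps concerned the ring nitrogen, so nothing was known about the group on the carbonyl carbon; in this assay, the swap from amino to 3-methyl-1,2,4-oxadiazol-5-yl gives an at least 8.0-fold higher number from compound 1 to compound 4 (0.90 log units; beyond the scatter). This position is therefore sensitive to change: with the ethyl on the ring nitrogen and the rest of the core left as they were, this one swap is enough to shift the read-out towards needing larger amounts of compound. Compound 4 is reported only as a limit and not as a number, and it is the second compound shown to stop there: the limit of > 25000 nM in this assay, at which 2 of the 4 values shown sit.

A single swap removes the amino group with its hydrogen-bond donor and brings in the larger aromatic ring, and these two events cannot be told apart from the compounds shown. From the compounds shown here alone, it remains open how a methylamino or hydroxyl group on the same carbonyl carbon would read, and whether the longer chain of compound 2 on the ring nitrogen would change the outcome for the 3-methyl-1,2,4-oxadiazol-5-yl group.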